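A Cyano for Fluoro Swap on a Cytotoxicity Read-out

The source may hold more compounds than are shown below. What is called first, only, known or untested is meant among the compounds shown, and "the series" means these compounds.

Compound 2 `C/C(=C\c1cc(-c2ccc(F)cc2)cs1)C(N)=O` was examined in an ADME assay on NIH3T3 cells (Mus musculus) for cytotoxicity, read by CCK-8 assay, with a stated time of 24 h; on this read-out lower numbers stand for stronger inhibition and higher numbers for weaker inhibition. There compound 2 gives > 50000 nM, which is a limit of the assay and not a number. Compound 1 `C/C(=C\c1cc(-c2ccccc2)cs1)C(N)=O` is the unsubstituted parent, and in this assay compound 1 gives > 50000 nM, again a limit rather than a number. The step from compound 1 to compound 2, a step that the two limits leave unreadable from compound 1 to compound 2, is unreadable from the two limits, and the evidence amounts to the limit of > 50000 nM in this assay, at which 2 of the 2 values shown sit. Compound 3 `C/C(=C\c1cc(-c2ccc(C#N)cc2)cs1)C(N)=O` is not yet measured. It differs from compound 2 by cyano in place of fluoro on an aromatic carbon, the cyano entering on an aromatic carbon of a six-membered aromatic ring of carbon only, para to a large group. Within the data shown here, no measured step bears readably on this change; the one step in hand is bounded on both sides by limits. The expectation for compound 3 in this assay is accordingly a further limit with no number, and the step that the limit leaves unreadable from compound 2 to compound 3 is expected to stay unreadable against the scatter. Compound 3 is estimated at 100000 nM, between 30000 nM and 400000 nM.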

Compound 3, half-maximal inhibitory concentration: > 50000 nM
Compound 3 ended at the assay's limit (the forecaster's own chance of this, stated with the estimate: 85%); the middle value lies beyond the limit too.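

Compound 3 sits at the same limit of this assay as compound 1 and compound 2, so no step among these three compounds can be read: the limit of > 50000 nM in this assay, at which 3 of the 3 values shown sit.

The compounds shown leave open whether hydrogen, fluoro or cyano at this place makes any difference in this assay, since none of the three gives a number there.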